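Working notes on the aryl amine exchange from compound 1

The compounds below may be only part of what the source reports. "The series", "measured", "known", "first", "only" and "open" are said of these compounds alone.

Compound 1 `COc1ccc(Nc2nc(Oc3cccc(NC(=O)C=C(C)C)c3)c3sccc3n2)cn1` is read in a functional assay on HeLa cells (Homo sapiens) for inhibition, read by MTT assay, with a stated time of 72 h; a lower number here means a stronger inhibitor, a higher number a weaker inhibitor. In this assay compound 1 gives > 100000 nM, which is a limit of the assay and not a number. Its one measured partner, compound 2 `COc1ccc(Nc2nc(Oc3cccc(NC(=O)/C=C/C(C)C)c3)c3sccc3n2)cn1`, differs on the carbonyl carbon by 3-methylbut-1-en-1-yl in place of 2-methylprop-1-en-1-yl. In this assay compound 2 gives > 50000 nM, again a limit and not a number. The step that the two limits leave unreadable from compound 1 to compound 2 therefore cannot be read, since both ends sit at limits (the limit of > 100000 nM in this assay, at which 1 of the 2 values shown sits, (the limit of > 50000 nM in this assay, at which 1 of the 2 values shown sits)). Going by the values given here, compound 1 thus stands only at a limit, and the single other value shown is a limit as well.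

Compound 3 `CC(C)=CC(=O)Nc1cccc(Oc2nc(Nc3cccc(C#N)c3)nc3ccsc23)c1` carries the change 3-cyanophenyl in place of 6-methoxypyridin-3-yl on a nitrogen on an aromatic ring whose other neighbours are aromatic carbon. Among the compounds with values here, no measured step touches this position; the only measured step concerns the group on the carbonyl carbon and is itself unreadable. No direction can be drawn from the data, so the working expectation is that compound 3 stays near the limit. For compound 3 the estimated value in this assay is 80000 nM, with a range from 15000 nM to 300000 nM. The estimated step of an at least 1.2-fold lower number from compound 1 to compound 3 (0.09 log units; that floor lies within the scatter) is accordingly only a nominal one.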

Compound 3, half-maximal inhibitory concentration: 19800 nM
The estimate for compound 3 lay 4.0-fold (0.61 log units) above the measured number; the measured number falls inside the stated range.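

In this assay, 3-cyanophenyl in place of 6-methoxypyridin-3-yl on a nitrogen on an aromatic ring gives an at least 5.0-fold lower number from compound 1 to compound 3 (0.70 log units; beyond the scatter), the only readable step among the compounds shown and one that moves the series from limits to a number. This shows that the group on this nitrogen can change the read-out, which the earlier pair could not show: its step on the carbonyl carbon cannot be read, as both ends are limits. The size of the new step is only a floor, since the value of compound 1 is a limit and not a number: the limit of > 100000 nM in this assay, at which 1 of the 3 values shown sits.

The exchange removes the methoxy group and the ring nitrogen and adds the nitrile in a single step, so the compounds shown do not tell which of these differences carries it, nor how a plain phenyl or a phenyl bearing a carboxylic acid would read on the same nitrogen. Also open, from the compounds shown here alone, is whether the 3-cyanophenyl step holds with the 3-methylbut-1-en-1-yl group on the carbonyl carbon.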